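Cytotoxicity notes on a benzyl substituent exchange

The source may report more compounds than this note shows. Statements on the series, on what has been measured and on what is new or still open speak of the compounds shown alone.

Measured compounds:
Compound 1, `COC(=O)c1ccc(NCc2cncn2Cc2ccccc2C(C)(C)C)cc1-c1ccccc1` — in a toxicity assay on NIH3T3 cells (Mus musculus) for cytotoxicity, read by resazurin assay (a higher number here means that more compound is needed for the effect, a lower number that less compound is needed), compound 1 gives "not determined" (no result reported).
Compound 2, `COC(=O)c1ccc(NCc2cncn2Cc2cccc(C)c2)cc1-c1ccccc1` — in this assay compound 2 gives > 10000 nM.

Compound 2 stands at a limit of this assay, not at a number: its entry is a limit only, and the limit of > 10000 nM in this assay, at which 1 of the 2 values shown sits, describes where it sits. Among the compounds with values here, compound 1 carries no result in this assay at all, so no step between measured compounds can be drawn, and nothing here shows how a change on the benzyl part moves the read-out.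

Compound 3, `COC(=O)c1ccc(NCc2cncn2Cc2ccccc2Cl)cc1-c1ccccc1`, is the next entry for this assay. It differs from compound 2 by 2-chlorophenyl in place of 3-methylphenyl on a saturated chain carbon bound to an aromatic nitrogen.

Within the data shown here, with no measured step to lean on, the expectation for compound 3 rests on compound 2 alone, which gives only a limit. The step from compound 2 to compound 3 is expected to stay within the usual scatter, a step that the limit leaves unreadable from compound 2 to compound 3, with no direction claimed. Compound 3 is estimated at 15000 nM in this assay, with a range from 5000 nM to 50000 nM, and a repeat of a limit-only entry is expected to be the most likely outcome.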

Compound 3, half-maximal effective concentration: 10000 nM
For compound 3 the middle estimate is 1.5-fold (0.18 log units) above the measured one; the measured number falls inside the stated range.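

Within the data shown here, compound 3 gives the first single number of the series in this assay, 10000 nM, which makes the benzyl position readable for the first time rather than only bounded. The exchange of 3-methylbenzyl to 2-chlorobenzyl, with the place on a saturated chain carbon bound to an aromatic nitrogen unchanged, gives a number no higher from compound 2 to compound 3 (the limit leaves the size open), and the two groups match in heavy-atom count and in carrying no hydrogen-bond donors or acceptors. The reading of this step ends at a limit and not at a second number, and compound 2 supplies that limit: the limit of > 10000 nM in this assay, at which 1 of the 3 values shown sits.

Still open, on these data alone, is whether the step is real or lies within ordinary repeat variation, and whether any change comes from the chlorine or from its place on the ring, which 2-methylphenyl or 3-chlorophenyl at the same position would separate. Also open, as far as these compounds go, is how the read-out responds to a group of a different kind on the benzyl ring, such as an amine or a carboxylic acid, and to the larger 2-tert-butyl group of compound 1, which has no result here.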